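Swapping a Ring on the Sulfonamide Nitrogen

This account rests on a few compounds, and the source may have more. Where it says the series, first, only, none or still open, it means among the compounds named here.

Of the compounds shown here, three built on one shared core have been measured in a functional assay on HT-1080 cells (Homo sapiens) for antiproliferative activity, read by sulforhodamine B assay, with a stated time of 48 h; a lower number here means a stronger inhibitor, a higher number a weaker inhibitor. Compound 1 `Nc1ccc(S(=O)(=O)Nc2ccnc3cc(C(F)(F)F)ccc23)cc1` gives 29600 nM in this assay. Compound 2 `O=C(Nc1ccccc1)Nc1ccc(S(=O)(=O)Nc2ccnc3cc(C(F)(F)F)ccc23)cc1` gives 25400 nM. Within the data shown here, the only pair differing in a single place shows a 1.2-fold lower number from compound 1 to compound 2 (0.07 log units; within the scatter), a change that stays within the scatter. Compound 3 `Cc1cc(NS(=O)(=O)c2ccc(N/C(S)=N\c3ccnc4cc(C(F)(F)F)ccc34)cc2)on1` gives 27300 nM in this assay; its number is the second highest of the three, but all three values sit within the scatter of one another, so no order among them can be claimed.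

Compound 4 `O=S(=O)(Nc1ncccn1)c1ccc(N/C(S)=N\c2ccnc3cc(C(F)(F)F)ccc23)cc1` has not yet been measured. It differs from compound 3 by pyrimidin-2-yl in place of 3-methyl-1,2-oxazol-5-yl on a sulfonamide nitrogen. Among the measured compounds shown here, no measured step touches this position, and the single measured step elsewhere was within the scatter, while all three measured numbers cluster closely. For compound 4 the expected step is therefore a 1.0-fold lower number from compound 3 to compound 4 (0.00 log units; within the scatter), nothing beyond the scatter. Compound 4 is expected to give 27000 nM in this assay, within a range from 12000 nM to 60000 nM.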

Compound 4, half-maximal inhibitory concentration: 29100 nM
Compound 4: middle estimate off by 1.1-fold (0.03 log units), on the low side; measured number inside the range.
By their numbers in this assay, from the lowest: compounds 2, 3, 4 and 1 (each within the scatter of the next).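

In this assay, the first change measured on the sulfonamide nitrogen, pyrimidin-2-yl in place of 3-methyl-1,2-oxazol-5-yl, gives a 1.1-fold higher number from compound 3 to compound 4 (0.03 log units; within the scatter) and so shows no readable effect. At this position, a five-membered aromatic ring and a six-membered aromatic ring, each with 2 hetero atoms, therefore cannot be told apart by this read-out. No accompanying measurement offers an explanation for this result.

On these data alone, both rings compared are aromatic and contain hetero atoms, so it remains open whether a plain phenyl ring, a methyl group or a longer alkyl chain on this nitrogen would give a different number. As far as these compounds go, it is also open whether adding an amine or a carboxylic acid to the pyrimidin-2-yl ring would move the number beyond the scatter.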